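Sulfonyl indole carboxamides: cytotoxicity, compound 4 ahead

The source may report more compounds than this note shows. Statements on the series, on what has been measured and on what is new or still open speak of the compounds shown alone.

Measured in an ADME assay on CCRF-CEM cells (Homo sapiens) for cytotoxicity, read by cell counting (on this read-out higher numbers stand for lower toxicity in this test and lower numbers for higher toxicity in this test), so far:
- compound 1, `Cc1cc(C)cc(S(=O)(=O)c2c(C(=O)NCc3ccccc3)[nH]c3ccc(Cl)c(F)c23)c1`: 15000 nM
- compound 2, `Cc1cc(C)cc(S(=O)(=O)c2c(C(=O)NCN3CCCCC3)[nH]c3ccc(Br)cc23)c1`: 10000 nM
- compound 3, `Cc1cc(C)cc(S(=O)(=O)c2c(C(=O)NCN3CCCCC3)[nH]c3ccc(Cl)cc23)c1`: 9900 nM

Compound 2 holds the second highest of the three numbers in this assay. Its nearest neighbour is compound 3, reached by a 1.0-fold lower number from compound 2 to compound 3 (0.00 log units; within the scatter); its furthest is compound 1, whose number stands a little higher but still within the scatter. The three compounds thus sit together with no separation that counts.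

The next compound in line is compound 4, `Cc1cc(C)cc(S(=O)(=O)c2c(C(=O)NCc3ccccc3)[nH]c3ccc(Br)cc23)c1`. It derives from compound 2 by phenyl in place of piperidin-1-yl on a saturated chain carbon bound to an amide-type nitrogen. Going by the values given here, no measured step covers this change: the only step available, from compound 2 to compound 3, swaps a halogen on an aromatic carbon and lies flat. Compound 1 does carry the benzylcarbamoyl arm, but it also differs from compound 2 in its aromatic halogens, so only its two values can be compared, and they lie within the scatter of each other.

With nothing pointing to a shift in either direction, compound 4 is expected to show no step beyond the scatter in this assay, that is a 1.2-fold higher number from compound 2 to compound 4 (0.08 log units; within the scatter). The estimate for compound 4 is therefore 12000 nM, with a range of 5000 nM to 30000 nM.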

Compound 4, half-maximal cytotoxic concentration: 172000 nM
Estimate against measurement, compound 4: 14-fold (1.16 log units) below, outside the stated range (above it).
By their numbers in this assay, from the lowest: compounds 3, 2 and 1 (each within the scatter of the next); then compound 4.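

In this assay the saturated chain carbon bound to the amide-type nitrogen proves to be a sensitive place: the exchange of piperidin-1-yl for phenyl gives a 17-fold higher number from compound 2 to compound 4 (1.24 log units; beyond the scatter), a large step towards lower toxicity in this test. Going by these compounds alone, the earlier series showed only a flat change, the swap of halogen on an aromatic carbon, with a 1.0-fold lower number from compound 2 to compound 3 (0.00 log units; within the scatter), so the first step beyond the scatter comes from this arm and not from the halogen. The two groups have the same heavy-atom count, 6, and both carry no net charge, so the step goes with what differs under that count: a six-membered non-aromatic ring with one nitrogen leaves, and a six-membered aromatic ring of carbon only enters, though nothing at hand bears on why the step is this large.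

Open, from the compounds shown here alone, is whether the step follows the loss of the ring nitrogen or the arrival of the aromatic ring, a question that cyclohexyl on the same carbon would separate. Also open, going by these compounds, is how a longer chain ending in phenyl, or an open-chain amine such as dimethylamino, would read at this place, and whether the halogen swap stays flat with the benzylcarbamoyl arm in place.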